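A few compounds are considered here, and "the series" means these few. Any claim that something is new, unique, unknown or untested is made for them only; others in the source may bear on it.

Of the compounds shown here, two with the same core have been measured so far. In a functional assay on PC-3 cells (Homo sapiens) for inhibition, read by sulforhodamine B assay (on this read-out higher numbers stand for weaker inhibition of growth and lower numbers for stronger inhibition of growth), compound 1 `Cc1ccc2[nH]c(-c3ccc(-c4ccc(-c5ccc(N(C)C)cc5)cc4)cc3)nc2c1` gives 8120 nM and compound 2 `Cc1ccc2[nH]c(-c3ccc(-c4ccc(-c5ccc(C(F)(F)F)cc5)cc4)cc3)nc2c1` gives 2010 nM, so compound 2 holds the lower of the two numbers and shows the stronger inhibition of growth. The next compound, compound 3 `Cc1ccc2[nH]c(-c3ccc(-c4ccc(-c5ccc(O)cc5)cc4)cc3)nc2c1`, carries hydroxy in place of trifluoromethyl on an aromatic carbon, at the same place on the ring where the first two compounds differ.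

For the measured compounds named here, only one measured step bears on this change: a 4.0-fold lower number from compound 1 to compound 2 (0.61 log units; beyond the scatter), a modest step beyond the scatter, made by putting trifluoromethyl in place of dimethylamino. Read backwards, it shows that the only other group tried at this place gave a higher number than trifluoromethyl. Going by the values given here, no compound with hydroxy has been measured yet, so this single comparison is thin evidence. A modest move towards a higher number in this assay is the likeliest outcome, and the expected step is a 2.2-fold higher number from compound 2 to compound 3 (0.35 log units; beyond the scatter). For compound 3 the estimated value is 4500 nM, with an expected range of 1400 nM to 14000 nM.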

Compound 3, concentration for 50% growth inhibition: 30000 nM
Compound 3: the middle estimate sits 6.7-fold (0.82 log units) below what was measured; the measured number lies above the stated range.
By their numbers in this assay, from the lowest: compound 2; then compound 1; then compound 3.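

In this assay, the group on this aromatic carbon, para to a large group, can change the number far more than the first pair suggested: hydroxy in place of trifluoromethyl gives a 15-fold higher number from compound 2 to compound 3 (1.17 log units; beyond the scatter), a large step. Hydroxy also falls behind dimethylamino, with a 3.7-fold higher number from compound 1 to compound 3 (0.57 log units; beyond the scatter), a modest step, so compound 3 is the weakest of the three and the order from strongest to weakest is trifluoromethyl, dimethylamino, hydroxy. Nothing available explains why hydroxy does worst at this place.

For the compounds shown here, with only three groups compared, these compounds do not show whether the order reflects a general trend at this position or just these particular substituents. A methoxy group, a chlorine atom or a nitrile at the same place could show whether the loss is specific to hydroxy, and whether any group can give stronger inhibition of growth than compound 2, which gives 2010 nM.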